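Replacing chlorophenyl by hydroxy-methoxyphenyl on the hydrazone

This account rests on a few compounds, and the source may have more. Where it says the series, first, only, none or still open, it means among the compounds named here.

Compound 3 `CN(C)CCn1cnnc1-c1cc(Oc2ccc(NC(=O)N/N=C/c3ccc(Cl)cc3)cc2F)ccn1` gives 1370 nM in a functional assay on U-87MG ATCC cells (Homo sapiens) for cytotoxicity, read by MTT assay, with a stated time of 72 h (a higher number here means a weaker inhibitor, a lower number a stronger inhibitor), the lowest of the two numbers recorded there. Its nearest neighbour is compound 2 `CN(C)CCn1cnnc1-c1cc(Oc2ccc(NC(=O)N/N=C/c3cccc(Cl)c3Cl)cc2F)ccn1` with 13200 nM, separated by a 9.6-fold lower number from compound 2 to compound 3 (0.98 log units; beyond the scatter). Compound 1 `CN(C)CCn1cnnc1-c1cc(Oc2ccc(NC(=O)N/N=C/c3ccc(O)c(O)c3)cc2F)ccn1` reaches only the limit of the assay, > 100000 nM. Compound 4 `COc1ccc(/C=N/NC(=O)Nc2ccc(Oc3ccnc(-c4nncn4CCN(C)C)c3)c(F)c2)cc1O` differs from compound 3 in one place: 3-hydroxy-4-methoxyphenyl in place of 4-chlorophenyl on a carbon with a double bond to nitrogen. The measured step that bears on this is an at least 72-fold lower number from compound 1 to compound 3 (1.86 log units; beyond the scatter), where the two hydroxyls gave way to chlorine and the number fell from a limit to a clear value. Compound 4 brings back one hydroxyl beside a methoxy group, so the step of a 22-fold higher number from compound 3 to compound 4 (1.34 log units; beyond the scatter) is expected to be a large rise because an at least 72-fold lower number from compound 1 to compound 3 (1.86 log units; beyond the scatter) ran so strongly the other way. Compound 4 is estimated at 30000 nM, between 8000 nM and 120000 nM.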

Compound 4, half-maximal inhibitory concentration: > 100000 nM
Compound 4: no number, only a limit (the forecaster's own chance of this, stated with the estimate: 30%); at least 3.3-fold (0.52 log units) between middle value and limit.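

Compound 4 carries a methoxy group where compound 1 has one of its two hydroxyls, yet its reading in this assay is again only a limit and not a number: the limit of > 100000 nM in this assay, at which 2 of the 4 values shown sit.

Methylating that hydroxyl therefore does not bring back a readable value, and the chlorine-bearing compounds stay well clear of the limit, with an at least 72-fold higher number from compound 3 to compound 4 (1.86 log units; beyond the scatter) and an at least 7.5-fold higher number from compound 2 to compound 4 (0.87 log units; beyond the scatter). The step from compound 1 to compound 4 cannot be read, as both values are limits.

On these data alone, whether any oxygen substituent on this ring gives the same result remains open. A 4-methoxyphenyl or a 4-aminophenyl on that carbon could separate these possibilities.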